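Series notes: aromatic substituent change on the way to compound 4

This account rests on a few compounds, and the source may have more. Where it says the series, first, only, none or still open, it means among the compounds named here.

Measured compounds:
compound 1 `CCCCNc1ccnc2cc(F)ccc12`: in a functional assay on MDA-MB-231 cells (Homo sapiens) for cytotoxicity, read by sulforhodamine B assay, with a stated time of 48 h, in the presence of a further agent that is not named here (on this read-out lower numbers stand for stronger inhibition of growth and higher numbers for weaker inhibition of growth), compound 1 gives 12300 nM
compound 2 `CN(C)CCNc1ccnc2cc(Cl)ccc12`: in this assay compound 2 gives 9880 nM
compound 3 `CN(C)CCNc1ccnc2cc(F)ccc12`: in this assay compound 3 gives 9450 nM

Compound 3 sits at one end of these three numbers, but the step of a 1.3-fold lower number from compound 1 to compound 3 (0.11 log units; within the scatter) and the step of a 1.0-fold lower number from compound 2 to compound 3 (0.02 log units; within the scatter) both lie within the scatter, so the three compounds are not separated from one another by these measurements.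

Compound 4 `COc1ccc2c(NCCN(C)C)ccnc2c1` has not yet been measured in this assay. Relative to compound 3 the change is methoxy in place of fluoro on an aromatic carbon. Among the compounds with values here, the only measured step at the same aromatic carbon is a 1.0-fold lower number from compound 2 to compound 3 (0.02 log units; within the scatter), which was within the scatter; no measured step involves a methoxy group, so nothing here points to a change beyond the scatter in either direction.

Compound 4 is therefore expected near 9500 nM in this assay, with a range from 4500 nM to 20000 nM. This estimate means a step of a 1.0-fold higher number from compound 3 to compound 4 (0.00 log units; within the scatter), which is expected to remain within the scatter.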

Compound 4, concentration for 50% growth inhibition: 9450 nM
The estimate for compound 4 lay 1.0-fold (0.00 log units) above the measured number; measured number inside the range.
By their numbers in this assay, from the lowest: compounds 3, 4, 2 and 1 (each within the scatter of the next).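

Methoxy in place of fluoro on this aromatic carbon gives no change at the digits printed from compound 3 to compound 4 (within the scatter) in this assay, and methoxy in place of chloro gives a 1.0-fold lower number from compound 2 to compound 4 (0.02 log units; within the scatter). The earlier compounds shown here compared only fluoro and chloro here; this carbon, meta to a fused ring and para to a fused ring, now also takes a group of two heavy atoms with one hydrogen-bond acceptor, and the values of compounds 2, 3 and 4 remain within the scatter of each other. No supporting measurement bears on why these three groups read alike.

From the compounds shown here alone, whether an amine, a carboxylic acid or a nitrile on this carbon would also stay within the scatter remains open. Also open, going by these compounds, is whether a longer chain ending in dimethylamino would shift the number with methoxy on the core.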